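Replacing a biphenyl with a nitrile-bearing ring: cytotoxicity outlook

This account rests on a few compounds, and the source may have more. Where it says the series, first, only, none or still open, it means among the compounds named here.

Compound 1 `COC(=O)c1ccc(NCc2cncn2Cc2ccccc2-c2ccccc2)cc1-c1ccccc1` carries a 2-phenylphenyl group on a saturated chain carbon bound to an aromatic nitrogen. In a toxicity assay on NIH3T3 cells (Mus musculus) for cytotoxicity, read by resazurin assay (on this read-out lower numbers stand for an effect already at smaller amounts and higher numbers for an effect only at larger amounts of compound), compound 1 gives "not determined" (no result reported), so its own standing on this read-out is open. Two related compounds set the frame. Compound 2 `COC(=O)c1ccc(NCc2cncn2Cc2ccc(-c3ccccc3)cc2)cc1` reaches only the limit of the assay, giving > 10000 nM in this assay. Compound 3 `c1ccc(-c2ccc(Cn3cncc3CNc3ccccc3-c3ccccc3)cc2)cc1` likewise returns only a limit, > 10000 nM in this assay. Because (the limit of > 10000 nM in this assay, at which 2 of the 3 values shown sit), both neighbours of compound 1 show no measurable cytotoxicity within the tested range.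

Compound 4 `COC(=O)c1ccc(NCc2cncn2Cc2ccc(C#N)cc2)cc1-c1ccccc1` differs from compound 1 by 4-cyanophenyl in place of 2-phenylphenyl on a saturated chain carbon bound to an aromatic nitrogen. For the measured compounds named here, no measured pair shares this exact change, so no size for the step in this assay can be read off; the expectation is no shift beyond the scatter, with compound 4 most likely again sitting at the limit. Compound 4 is expected to give about 15000 nM in this assay, within a range from 8000 nM to 40000 nM.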

Compound 4, half-maximal effective concentration: > 10000 nM
Compound 4 was reported as a limit; the forecaster's own chance of this, stated with the estimate: 80%; the middle value is on the limit's open side.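

For the compounds shown here, neither compound 1 nor compound 4 has a single number in this assay, so no step between them can be read. The compounds shown leave open where the true values lie beyond the limit, and whether 4-cyanophenyl in place of 2-phenylphenyl changes cytotoxicity at all.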